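Trimming compound 1 towards compound 3

The source may hold more compounds than are shown below. What is called first, only, known or untested is meant among the compounds shown, and "the series" means these compounds.

Compound 1 `COc1cc(-c2nn(-c3cccc(NC(=O)Nc4ccc(Cl)c(Cl)c4)c3)cc2-c2ccncc2)ccc1Cl` was tested in a functional assay on MCF7 cells (Homo sapiens) for inhibition, read by sulforhodamine B assay, with a stated time of 48 h; a higher number here means a weaker inhibitor of growth, a lower number a stronger inhibitor of growth. In this test, compound 1 gives only a limit, > 50000 nM, and not a number. A close relative is compound 2 `O=C(Nc1cccc(-n2cc(-c3ccncc3)c(-c3ccc(Cl)c(O)c3)n2)c1)Nc1ccc(Cl)c(Cl)c1`. Compound 2 also gives only a limit, > 32500 nM.

Among the compounds with values here, the one measured step is a step that the two limits leave unreadable from compound 1 to compound 2, which puts hydrogen in place of methyl on an oxygen on an aromatic ring. That step has no readable size, so it offers nothing to carry forward. It also lies in a different place from the change considered here.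

Compound 3 `COc1cc(-c2nn(-c3cccc(NC(=O)c4ccccc4)c3)cc2-c2ccncc2)ccc1Cl` has phenyl in place of (3,4-dichlorophenyl)amino on a carbonyl carbon. Within the data shown here, no measured step covers this exchange, so the data give neither a size nor a direction for it. The expectation therefore rests on compound 1 and its limit of > 50000 nM, and no clear shift in this assay is expected. For compound 3, the estimated step is an at least 1.1-fold lower number from compound 1 to compound 3 (0.04 log units; that floor lies within the scatter), and this is a loose expectation. For compound 3, the expected value is 45000 nM, with an estimated range from 12000 nM to 100000 nM.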

Compound 3, concentration for total growth inhibition: > 100000 nM
Compound 3 ended at the assay's limit; the forecaster's own chance of this, stated with the estimate: 65%; at least 2.2-fold (0.34 log units) between middle value and limit.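

Compound 3 gives only a limit in this assay, > 100000 nM, and not a number. Compound 1 also gives only a limit, > 50000 nM. These two limits leave no readable step between compound 1 and compound 3. The compounds shown leave open what size or direction, if any, the exchange of (3,4-dichlorophenyl)amino for phenyl has in this assay.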